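From methoxy to methyl: what to expect for compound 4

This account rests on a few compounds, and the source may have more. Where it says the series, first, only, none or still open, it means among the compounds named here.

Of the compounds shown here, three have been measured in a functional assay on HepG2 cells (Homo sapiens) for inhibition, read by MTT assay, with a stated time of 72 h (on this read-out higher numbers stand for weaker inhibition and lower numbers for stronger inhibition), so far.

Compound 1 `COc1ccc(/C=C/C(=O)c2c(OC)cc(O)c(CC=C(C)C)c2O)cc1` gives 32400 nM
Compound 2 `COc1cc(O)c(CC=C(C)C)c(O)c1C(=O)/C=C/c1cccc([N+](=O)[O-])c1` gives 16600 nM
Compound 3 `COc1ccc(/C=C/C(=O)c2c(O)cc(O)cc2OC)cc1` gives 18100 nM

All three numbers lie within the usual scatter of one another, so compound 3 at 18100 nM holds no real rank among them. Compound 4 `COc1cc(O)cc(O)c1C(=O)/C=C/c1ccc(C)cc1` is still unmeasured and differs from compound 3 by methyl in place of methoxy on an aromatic carbon with methyl in place of methoxy on an aromatic carbon, para to a large group. Within the data shown here, no measured step makes this exact swap. The closest evidence is 3-nitrophenyl in place of 4-methoxyphenyl, which gave a 2.0-fold lower number from compound 1 to compound 2 (0.29 log units; within the scatter) as its result, and hydrogen in place of 3-methylbut-2-en-1-yl, which gave a 1.8-fold lower number from compound 1 to compound 3 (0.25 log units; within the scatter) as its result. Both stay within the scatter, so only a small change is expected, with neither direction favoured. The estimated step in this assay is a 1.0-fold lower number from compound 3 to compound 4 (0.00 log units; within the scatter) in size, which means none beyond the scatter. For compound 4 the estimated value is 18000 nM with an expected range from 8000 nM to 40000 nM in this measurement.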

Compound 4, half-maximal inhibitory concentration: > 50000 nM
Compound 4: only a limit was reported; the forecaster's own chance of this, stated with the estimate: 5%; at least 2.7-fold (0.44 log units) between middle value and limit.
By their numbers in this assay, from the lowest: compounds 2, 3 and 1 (each within the scatter of the next). At a limit, above all of these: compound 4.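

Methyl in place of methoxy, para to a large group, gives the first change here that goes beyond the scatter: in this assay it produces an at least 2.7-fold higher number from compound 3 to compound 4 (0.44 log units; beyond the scatter). This does not make the methoxy group a general requirement, and compound 2 goes against such a rule: it carries 3-nitrophenyl in place of 4-methoxyphenyl, yet a 2.0-fold lower number from compound 1 to compound 2 (0.29 log units; within the scatter). Compound 4 is reported only as a limit, so the full size of its step stays unknown: the limit of > 50000 nM in this assay, at which 1 of the 4 values shown sits.

The compounds shown leave open whether the result reflects losing the methoxy group or gaining the methyl group. An amine or an ethoxy group at the same place on the core of compound 3 would help to separate these two readings.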